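Pyridinyl for Methyl on the Piperazine: What to Expect

The source may report more compounds than this note shows. Statements on the series, on what has been measured and on what is new or still open speak of the compounds shown alone.

Measured compounds:
compound 1, `COc1cc2c(Nc3ccc(C#N)cc3)ncnc2cc1OCCCN1CCc2ccccc2C1`; in a functional assay on A549 cells (Homo sapiens) for antiproliferative activity, read by MTT assay, with a stated time of 72 h (a lower number here means a stronger inhibitor, a higher number a weaker inhibitor), compound 1 gives > 100000 nM, which is a limit of the assay and not a number.
compound 2, `COc1cc2c(Nc3ccc(C#N)cc3)ncnc2cc1OCCCN1CCN(C)CC1`; in this assay compound 2 gives 48800 nM.

Compound 2 is thus the only one of the two measured compounds with an actual number in this assay. Compound 1 sits at the limit of > 100000 nM in this assay, at which 1 of the 2 values shown sits.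

Compound 3, `COc1cc2c(Nc3ccc(C#N)cc3)ncnc2cc1OCCCN1CCN(c2ccncc2)CC1`, differs from compound 2 in one place: pyridin-4-yl in place of methyl on an amine nitrogen in a ring. Within the data shown here, only one measured step bears on this change, an at least 2.0-fold lower number from compound 1 to compound 2 (0.31 log units; beyond the scatter), in which the amine that carried a ring system stood at the limit while the methyl-bearing piperazine gave a number. Among the measured compounds shown here, compound 3 again places a ring on the amine nitrogen, so the direction of that step, read backwards, is the only guide. Compound 3 is therefore expected to give a weaker result than compound 2, by a step estimated as a 1.7-fold higher number from compound 2 to compound 3 (0.24 log units; within the scatter). The estimate for compound 3 is 85000 nM, within a range from 30000 nM to 250000 nM, with a real chance that only a limit is reported.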

Compound 3, half-maximal inhibitory concentration: 25500 nM
Compound 3: middle estimate off by 3.3-fold (0.52 log units), on the high side, and the stated range ends above it.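

In this assay, pyridin-4-yl in place of methyl on the amine nitrogen of the piperazine gives a 1.9-fold lower number from compound 2 to compound 3 (0.28 log units; within the scatter), so the two compounds cannot be told apart at this position. This shows that an aromatic ring on that nitrogen does not by itself push a compound to the limit, something the earlier step could not show, and that the piperazine keeps its advantage over the 1,2,3,4-tetrahydroisoquinolin-2-yl amine whichever of the two groups it carries, with an at least 3.9-fold lower number from compound 1 to compound 3 (0.59 log units; beyond the scatter). The value of compound 1 remains a limit of the assay and not a number, so both steps from it give only a minimum size: the limit of > 100000 nM in this assay, at which 1 of the 3 values shown sits.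

Going by these compounds, what the pyridine nitrogen contributes stays open, since a phenyl group on the same piperazine nitrogen would be needed to separate it from the aromatic ring as such, and pyridin-2-yl or pyridin-3-yl would be needed to test where that nitrogen sits. Also open, on these data alone, is whether an acetyl or benzyl group at this position, or a shorter or longer chain leading to the piperazine, would move the number beyond the scatter.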